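From a Carbamate to a Benzoate

A few compounds are considered here, and "the series" means these few. Any claim that something is new, unique, unknown or untested is made for them only; others in the source may bear on it.

Of the compounds shown here, two have been measured in an ADME assay on a cell-free system (plasma, Homo sapiens) for metabolic stability; on this read-out higher numbers stand for a longer-lived compound and lower numbers for a shorter-lived compound. Compound 1, `O=C(OC[C@H]1O[C@@H](n2cc(F)c(=O)[nH]c2=O)C[C@@H]1OC(=O)[C@@H]1CCCN1)[C@@H]1CCCN1`, gives 0.1 h in this assay. Compound 2, `CCOC(=O)CN(C)C(=O)OCN(c1ccc([N+](=O)[O-])cc1Oc1ccccc1)S(C)(=O)=O`, gives 49.2 h in this assay and stands highest of the two, separated from compound 1 by a gap well beyond the usual scatter. Compound 3, `CS(=O)(=O)N(COC(=O)c1ccccc1)c1ccc([N+](=O)[O-])cc1Oc1ccccc1`, is not yet measured. It differs from compound 2 in one place: phenyl in place of ((ethoxycarbonyl)methyl)(methyl)amino on a carbonyl carbon. Going by the values given here, no pair of measured compounds differs in a single place, so the size of this step rests on judgement alone. A sizeable drop is expected, an 8.2-fold lower number from compound 2 to compound 3 (0.91 log units; beyond the scatter). Compound 3 is estimated at 6 h, somewhere between 0.5 h and 40 h.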

Compound 3, half-life: 0.0322 h
Compound 3: the middle estimate sits 190-fold (2.27 log units) above what was measured; measured number outside the range, below it.
By their numbers in this assay, from the lowest: compound 3; then compound 1; then compound 2.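

Replacing ((ethoxycarbonyl)methyl)(methyl)amino with phenyl on the carbonyl carbon, which turns the carbamate into a benzoate, gives a 1500-fold lower number from compound 2 to compound 3 (3.18 log units; beyond the scatter) in this assay and so a large step beyond the scatter. This shows that a change at this one place, with the rest of the compound kept the same, can decide how long the compound lasts. Nothing available here explains the size of this step.

Still open, from the compounds shown here alone, is whether the step comes from gaining the phenyl ring or from losing the nitrogen on the carbonyl carbon. A dimethylamino group or a short alkyl chain at this place would help separate the two.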